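Removing the aryl methoxy in the porcupine series

The source may hold more compounds than are shown below. What is called first, only, known or untested is meant among the compounds shown, and "the series" means these compounds.

Compound 3 `COc1ccc(-n2nc(C(=O)NCC(=O)Nc3nc4ccc(OC)cc4s3)c3ccccc3c2=O)cc1` stands second highest of the three numbers in an assay on L cells for inhibition of Protein-serine O-palmitoleoyltransferase porcupine (Mus musculus), read by reporter gene assay, with a stated time of 24 h (a lower number here means that less compound is needed, a higher number that more compound is needed for the effect), where compound 3 gives 60 nM. Going by the values given here, its nearest neighbour is compound 1 `COc1ccc2nc(NC(=O)CNC(=O)c3nn(-c4ccccc4OC)c(=O)c4ccccc34)sc2c1`, which in this assay gives 90 nM; the single step of a 1.5-fold lower number from compound 1 to compound 3 (0.18 log units; within the scatter) is within the scatter. Compound 2 `O=C(CNC(=O)c1nn(-c2ccccc2)c(=O)c2ccccc12)Nc1nc2ccc(Cl)cc2s1` gives 30 nM in this assay, but it differs from compound 3 in two places, so its value is only a reference point.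

Compound 4 `COc1ccc2nc(NC(=O)CNC(=O)c3nn(-c4ccccc4)c(=O)c4ccccc34)sc2c1` is not yet measured. It differs from compound 3 by hydrogen in place of methoxy on an aromatic carbon. Among the compounds with values here, the only measured step at this part of the molecule is a 1.5-fold lower number from compound 1 to compound 3 (0.18 log units; within the scatter), a move of the methoxy rather than its loss, and it stayed within the scatter. Within the data shown here, no measured pair shows the loss itself; compound 2 carries the bare phenyl but with a different substituent on the shared core. The expected step of a 1.2-fold lower number from compound 3 to compound 4 (0.08 log units; within the scatter) is therefore small, with no direction beyond the scatter. Compound 4 is estimated at 50 nM, with a range from 20 nM to 150 nM.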

Compound 4, half-maximal effective concentration: 210 nM
Compound 4: the middle estimate sits 4.2-fold (0.62 log units) below what was measured, outside the stated range (above it).
By their numbers in this assay, from the lowest: compounds 2, 3 and 1 (each within the scatter of the next, the first and the last beyond it); then compound 4.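

In this assay taking the methoxy off the aryl ring gives a 3.5-fold higher number from compound 3 to compound 4 (0.54 log units; beyond the scatter) and from the 2-methoxyphenyl form gives a 2.3-fold higher number from compound 1 to compound 4 (0.37 log units; beyond the scatter) while the earlier move of the methoxy stayed within the scatter, so in these pairs having a methoxy on this ring counts for more than where it sits. With the bare phenyl held fixed, the substituent on the shared core also carries weight, with methoxy in place of chloro giving a 7.0-fold higher number from compound 2 to compound 4 (0.85 log units; beyond the scatter) as the largest of the new steps. Nothing measured here accounts for these steps.

On these data alone, whether the oxygen is needed or any substituent would serve stays open, and a hydroxy, a fluoro or a methyl at the same place on the ring would separate these. Also open, as far as these compounds go, is how chloro on the shared core behaves alongside a 4-methoxyphenyl.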